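Hydroxamate carbonyl substituent swap in a 5-lipoxygenase series

This account rests on a few compounds, and the source may have more. Where it says the series, first, only, none or still open, it means among the compounds named here.

Measured compounds:
compound 1 `COc1cc(-c2cc3cc(C(C)N(O)C(C)=O)ccc3o2)cc(OC)c1OC` gives 310 nM
compound 2 `COc1ccc(C(=O)N(O)C(C)c2ccc3oc(-c4ccccc4)cc3c2)cc1OC` gives 200 nM

In an assay on RBL cells for inhibition of Polyunsaturated fatty acid 5-lipoxygenase (Rattus norvegicus) (on this read-out lower numbers stand for stronger inhibition and higher numbers for weaker inhibition), compound 2 holds the lower of the two numbers, but compound 1 sits within the scatter of it, so no order between the two can be read. The two compounds differ in more than one place, so their values stand side by side without a counted step.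

Compound 3 `CC(=O)OCC(=O)N(O)C(C)c1ccc2oc(-c3ccccc3)cc2c1` is not yet measured. It derives from compound 2 by acetoxymethyl in place of 3,4-dimethoxyphenyl on a carbonyl carbon. The shared core of compound 2 is kept unchanged. Among the compounds with values here, no step between measured compounds bears on this exchange. Within the data shown here, the only hint is that compound 1, which carries a short group on the same carbonyl carbon, gives 310 nM in this assay, a number within the scatter of compound 2. On that basis a step from compound 2 to compound 3 of a 1.8-fold higher number from compound 2 to compound 3 (0.24 log units; within the scatter) is expected, towards a somewhat higher number but not clearly beyond the scatter. Compound 3 is estimated at 350 nM, within 120 nM to 1000 nM.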

Compound 3, half-maximal inhibitory concentration: 160 nM
Compound 3: the middle estimate sits 2.2-fold (0.34 log units) above what was measured; the measured number falls inside the stated range.
By their numbers in this assay, from the lowest: compounds 3, 2 and 1 (each within the scatter of the next).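

In this assay the exchange of 3,4-dimethoxyphenyl for acetoxymethyl on a carbonyl carbon gives a 1.3-fold lower number from compound 2 to compound 3 (0.10 log units; within the scatter) and so no order between the two compounds can be read. Within the data shown here, this is the first counted step at this position, and it shows that a group with no ring and 5 heavy atoms can stand in place of an aromatic group with 10 heavy atoms without a change that can be told from the scatter, while the count of hydrogen-bond acceptors in the group stays the same and a double bond outside aromatic rings enters. No measurement on hand bears on why the two numbers stand level.

Whether this tolerance extends to other kinds of group on the same carbonyl carbon stays open, since a carboxylic acid, an amine or a longer alkyl chain there, with the rest of compound 2 kept unchanged, lies outside the compounds shown. Equally open, from the compounds shown here alone, is whether the ester within acetoxymethyl has any part in the number, which a plain methyl or a hydroxymethyl on that carbon in the shared core could address.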